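The compounds below may be only part of what the source reports. "The series", "measured", "known", "first", "only" and "open" are said of these compounds alone.

Two compounds of one series were tested in a functional assay on the whole organism (artery) with Rattus norvegicus as the target, with a stated time of 60 min, at a dose of 3 mg/kg by the intraduodenal route; on this read-out higher numbers stand for more inhibition at the one dose given (going by the name of the read-out) and lower numbers for less inhibition. Compound 1, `Cc1nc(C)c2c(n1)N(Cc1ccc(-c3ccccc3-c3nn[nH]n3)cn1)C(=O)CC2`, gives -34% in this assay. Compound 2, `Cc1nc2c(c(C(F)(F)F)n1)CCC(=O)N2Cc1ccc(-c2ccccc2-c2nn[nH]n2)nc1`, gives -41% in this assay. Compound 2 thus has the lower of the two numbers, but the number for compound 1 sits within the scatter of repeated measurements, so the two results cannot be told apart.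

Compound 3, `Cc1nc(C)c2c(n1)N(Cc1ccc(-c3ccccc3-c3nn[nH]n3)nc1)C(=O)CC2`, has not yet been measured in this assay. It differs from compound 2 in one place: methyl in place of trifluoromethyl on an aromatic carbon. Among the compounds with values here, no pair of measured compounds shows this change, so its effect is unknown from the data in hand. Given that both measured compounds fall close together, compound 3 is expected to land in the same region, with a step from compound 2 to compound 3 of a number 6 percentage points higher from compound 2 to compound 3 (within the scatter), which is not expected to exceed the scatter in either direction. Compound 3 is therefore estimated at -35% in this assay, in a range from -60% to -10%.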

Compound 3, a percentage reported as inhibition, in the whole organism at one dose (the size of the read-out at that dose, not a potency): -16%
Beside the measured number, compound 3's estimate is 19 percentage points below it; measured number inside the range.
By their numbers in this assay, from the lowest: compounds 2 and 1 (each within the scatter of the next); then compound 3.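

In this assay, within the data shown here, the exchange of trifluoromethyl for methyl on an aromatic carbon next to the ring nitrogen gives the first step that stands clear of the scatter: a number 25 percentage points higher from compound 2 to compound 3 (beyond the scatter). The earlier compounds shown here could not show this, since their two numbers could not be told apart; this pair shows that the read-out responds to the group at this position, with all else held the same, although compound 3 still gives a negative number at -16%. The size of the step rests on this single pair, and no separate measurement in hand bears on why the number moves.

As far as these compounds go, two groups at one position mark only two points, so it stays open where a hydrogen atom, a chlorine atom, an ethyl group or a methoxy group at this carbon would fall relative to compound 2 and compound 3. From the compounds shown here alone, it is also open whether the same exchange would give a step of similar size in the other compounds, or whether any group here would turn the number positive.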